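From 3-Phenylpropyl to Benzyloxy: Expecting Compound 3

This account rests on a few compounds, and the source may have more. Where it says the series, first, only, none or still open, it means among the compounds named here.

Compound 1 `Clc1ccc2[nH]c(SCc3ccccc3CCCc3ccccc3)nc2c1` has the lower of the two numbers measured in an assay on isolated protein for inhibition of Indoleamine 2,3-dioxygenase 1 (Homo sapiens), with a stated time of 60 min, tested at 10 uM (on this read-out lower numbers stand for less inhibition and higher numbers for more inhibition at the one concentration tested (going by the name of the read-out)), where compound 1 gives 19%. Compound 2 `c1ccc(CCc2ccccc2CSc2nc3ccccc3[nH]2)cc1` gives 43% in this assay, a gap beyond the usual scatter. Compound 3 `Clc1ccc2[nH]c(SCc3ccccc3OCc3ccccc3)nc2c1` is built from compound 1 by a single change: benzyloxy in place of 3-phenylpropyl on an aromatic carbon. Within the data shown here, no pair of measured compounds shows this change, so the expected step from compound 1 to compound 3 in this assay is a number 6 percentage points higher from compound 1 to compound 3 (within the scatter), a small rise that may well stay within the scatter. Compound 3 is therefore estimated at 25%, with a range from 5% to 50%.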

Compound 3, a percentage reported as inhibition, at one concentration (the size of the read-out at that concentration, not a potency): 3%
For compound 3 the middle estimate is 22 percentage points above the measured one; measured number below the stated range.
By their numbers in this assay, from the lowest: compound 3; then compound 1; then compound 2.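

Putting benzyloxy in place of 3-phenylpropyl on this aromatic carbon, ortho to a large group, gives in this assay a result of a number 16 percentage points lower from compound 1 to compound 3 (beyond the scatter), so the two groups are not interchangeable here. Both carry the same kind of aromatic ring, which shows that this ring alone does not set the number. Nothing available explains why the number falls. Open, as far as these compounds go, is how a longer chain, such as 5-phenylpentyl, would read at this position. Also open, from the compounds shown here alone, is whether an amine or a carboxylic acid at the end of the chain would change the picture.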